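Swapping 4-methylbenzyl for phenyl on the amide nitrogen

The source may hold more compounds than are shown below. What is called first, only, known or untested is meant among the compounds shown, and "the series" means these compounds.

Measured in a functional assay on HeLa cells (Homo sapiens) for cytotoxicity, read by MTT assay, with a stated time of 48 h; on this read-out lower numbers stand for stronger inhibition and higher numbers for weaker inhibition:
- compound 1 `COc1cc([C@@H]2C[C@]2(CO)C(=O)NCc2ccc(C)cc2)cc(OC)c1OC` gives 17400 nM
- compound 2 `CCOC(=O)[C@]1(C(=O)NCc2ccc(C)cc2)C[C@H]1c1cc(OC)c(OC)c(OC)c1` gives 28500 nM
- compound 3 `COc1cc([C@@H]2C[C@@]2(CO)C(=O)NCc2ccc(C)cc2)cc(OC)c1OC` gives 41200 nM

Compound 1 shares the low end of these numbers with compound 2, as the first step shows: a 1.6-fold higher number from compound 1 to compound 2 (0.21 log units; within the scatter). Compound 3 sits further off: a 2.4-fold higher number from compound 1 to compound 3 (0.37 log units; beyond the scatter). The next compound, compound 4 `COc1cc([C@@H]2C[C@]2(CO)C(=O)Nc2ccccc2)cc(OC)c1OC`, has not yet been measured. It departs from compound 1 by one change, phenyl in place of 4-methylbenzyl on an amide-type nitrogen.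

Neither measured step alters that group, and the second rests on (the fact that compounds 1 and 3 differ only in the configuration as drawn). These steps therefore bear on the new change only indirectly, by showing how narrow the spread is so far. Among the compounds with values here, with no direct precedent, the expectation in this assay is for no step beyond the scatter, and the direction stays open. The expected step is a 1.3-fold higher number from compound 1 to compound 4 (0.10 log units; within the scatter). For compound 4 the estimated value is 22000 nM, with an expected range of 7000 nM to 70000 nM.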

Compound 4, half-maximal inhibitory concentration: 32000 nM
For compound 4 the middle estimate is 1.5-fold (0.16 log units) below the measured one, and the stated range covers the measured number.
By their numbers in this assay, from the lowest: compounds 1, 2, 4 and 3 (each within the scatter of the next, the first and the last beyond it).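

The amide nitrogen is varied here for the first time among these compounds, and in this assay the exchange of 4-methylbenzyl for phenyl gives a 1.8-fold higher number from compound 1 to compound 4 (0.26 log units; within the scatter). The result shows that, with the rest of compound 1 held constant, this assay does not separate the two aromatic groups on this nitrogen, even though the methylene link and the ring methyl of 4-methylbenzyl are gone. Nothing available explains the size of this step.

The compounds shown do not tell whether a group of another kind on this nitrogen, such as a 2-phenylethyl chain, a pyridyl ring or a benzyl ring bearing a carboxylic acid, would move the number beyond the scatter. They also leave open whether phenyl would give a similar result with the other configuration of compound 3 or with the ethoxycarbonyl group of compound 2.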